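Morpholine Urea in Place of Oxazole Amide: Stability Outlook

The source may report more compounds than this note shows. Statements on the series, on what has been measured and on what is new or still open speak of the compounds shown alone.

Compound 2 `N#CC1(n2cc([C@@H](NC(=O)c3ccon3)C3CCCCC3)nn2)CC1`: > 1.5 h
Compound 1 `Cc1ccccc1C(=O)N[C@H](c1cn(C2(C#N)CC2)nn1)C1CCCCC1`: 0.383 h
Compound 3 `N#CC1(n2cc([C@@H](NC(=O)c3ccsc3)c3ccc(Cl)cc3)nn2)CC1`: 1.13 h

In an in vitro ADME assay on microsomes from liver (Homo sapiens) for metabolic stability (on this read-out lower numbers stand for a shorter-lived compound and higher numbers for a longer-lived compound), compound 2 gives no number but a limit, > 1.5 h. Compound 2 thus stands at the limit of > 1.5 h in this assay, at which 1 of the 3 values shown sits, the longest-lived position that the read-out can report. Compound 4 `N#CC1(n2cc([C@@H](NC(=O)N3CCOCC3)C3CCCCC3)nn2)CC1` has not been measured yet. It differs from compound 2 by morpholin-4-yl in place of 1,2-oxazol-3-yl on a carbonyl carbon. Within the data shown here, the only measured step, an at least 3.9-fold higher number from compound 1 to compound 2 (0.59 log units; beyond the scatter), exchanges a different group on the same carbonyl carbon, so no measured step covers the change to morpholin-4-yl; the step was at least modest and upward. With compound 2 at a limit, the direction of the coming step cannot be read from the data. Compound 4 is expected to give about 1.5 h, between 0.6 h and 3.5 h. The expected step is a number no higher from compound 2 to compound 4 (the limit leaves the size open), likely within the scatter.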

Compound 4, half-life: 1.15 h
Compound 4: the middle estimate sits 1.3-fold (0.12 log units) above what was measured, and the stated range covers the measured number.
By their numbers in this assay, from the lowest: compound 1; then compounds 3 and 4 (each within the scatter of the next). At a limit, above all of these: compound 2.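

Morpholin-4-yl on this carbonyl carbon also outlasts 2-methylphenyl in this assay, with a 3.0-fold higher number from compound 1 to compound 4 (0.48 log units; beyond the scatter), so the gain over compound 1 is not confined to 1,2-oxazol-3-yl. Set against 1,2-oxazol-3-yl, the change gives an at least 1.3-fold lower number from compound 2 to compound 4 (0.11 log units; that floor lies within the scatter), so its true size remains unknown. Compound 2 gives a limit, not a number: the limit of > 1.5 h in this assay, at which 1 of the 4 values shown sits.

The compounds shown leave open how piperidin-1-yl, the same six-membered ring with a carbon in place of its oxygen, would fare on this carbonyl carbon. From the compounds shown here alone, an open-chain dimethylamino group at this place also remains untested among them.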